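The source may hold more compounds than are shown below. What is called first, only, known or untested is meant among the compounds shown, and "the series" means these compounds.

In a functional assay on NCI-H460 cells (Homo sapiens) for cytotoxicity, read by MTT assay, with a stated time of 72 h (a higher number here means a weaker inhibitor, a lower number a stronger inhibitor), compound 1 `O=c1[nH]/c(=C\c2cccc(Oc3ccc(F)cc3)c2)c(=O)[nH]/c1=C\c1cccnc1` gives > 1000 nM, which is a limit of the assay and not a number. Among the measured compounds shown here, compound 2 `O=c1[nH]/c(=C\c2ccc(Br)o2)c(=O)[nH]/c1=C\c1cccc(Oc2ccc(F)cc2)c1` gives 361 nM, the only actual number so far. Compound 3 `O=c1[nH]/c(=C\c2ccc([N+](=O)[O-])o2)c(=O)[nH]/c1=C\c1cccc(Oc2ccc(F)cc2)c1` differs from it at one place: nitro in place of bromo on an aromatic carbon. For the measured compounds named here, the sole measured step, an at least 2.7-fold lower number from compound 1 to compound 2 (0.44 log units; beyond the scatter), introduced the 5-bromofuran-2-yl group and does not test a change on that group, so no step beyond the scatter is expected in this assay, and no direction is favoured. The expected step is a 1.2-fold lower number from compound 2 to compound 3 (0.08 log units; within the scatter). For compound 3 the estimated value is 300 nM, with an expected range of 80 nM to 1000 nM.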

Compound 3, half-maximal inhibitory concentration: > 1000 nM
Compound 3 gave a limit, no number; the forecaster's own chance of this, stated with the estimate: 10%; at least 3.3-fold (0.52 log units) between middle value and limit.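

In this assay, the group on the furan ring proves to matter: with nitro in place of bromo on the aromatic carbon next to the ring oxygen, the result is an at least 2.7-fold higher number from compound 2 to compound 3 (0.44 log units; beyond the scatter). A furan at this place is therefore not enough on its own, and 5-bromofuran-2-yl and 5-nitrofuran-2-yl are not interchangeable here. The full size of this step and the step between compound 1 and compound 3 cannot be read, as both compounds sit at a limit: the limit of > 1000 nM in this assay, at which 2 of the 3 values shown sit.

From the compounds shown here alone, it remains open whether bromo is specifically required at this carbon. How a chloro group or an amine would behave there is also unknown.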